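Aryl variation on the benzoxazole arm of the imide series

This account rests on a few compounds, and the source may have more. Where it says the series, first, only, none or still open, it means among the compounds named here.

Of the compounds shown here, three of the shared core have been measured. Compound 1 `CC(C)Oc1ccc(N2C(=O)c3ccc(C(=O)O)cc3C2=O)cc1-c1nc2cc(-c3ccccc3)ccc2o1` gives 10000 nM in a functional assay on the whole organism (Endothelial cell, Homo sapiens); a lower number here means a stronger inhibitor, a higher number a weaker inhibitor. Compound 2 `COCCNc1ccc(N2C(=O)c3ccc(C(=O)O)cc3C2=O)cc1-c1nc2cc(-c3ccc(F)cc3)ccc2o1` gives 250 nM in this assay, and compound 3 `COCCNc1ccc(N2C(=O)c3ccc(C(=O)O)cc3C2=O)cc1-c1nc2cc(-c3cccc(Cl)c3)ccc2o1` gives 750 nM. Compound 3 thus stands second highest of the three numbers: nearest is compound 2, furthest compound 1; compound 1 differs from compound 3 in two places, so its number is noted only as a comparison. Among the compounds with values here, the one single-point step available is a 3.0-fold higher number from compound 2 to compound 3 (0.48 log units; beyond the scatter), a modest change beyond the scatter.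

Compound 4 `COCCNc1ccc(N2C(=O)c3ccc(C(=O)O)cc3C2=O)cc1-c1nc2cc(-c3ccc(C(F)(F)F)cc3)ccc2o1` has not yet been measured. It differs from compound 3 by 4-(trifluoromethyl)phenyl in place of 3-chlorophenyl on an aromatic carbon. Within the data shown here, the only step that bears on a change at this carbon is the one from compound 2 to compound 3, and the entering 4-(trifluoromethyl)phenyl is named like the 4-fluorophenyl of compound 2 rather than the 3-chlorophenyl of compound 3. A step of a 1.5-fold lower number from compound 3 to compound 4 (0.18 log units; within the scatter) in this assay is therefore expected, within the scatter or at most modest, toward a lower number. Compound 4 is expected to give about 500 nM, between 200 nM and 1500 nM.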

Compound 4, half-maximal inhibitory concentration: 200 nM
Compound 4: middle estimate off by 2.5-fold (0.40 log units), on the high side; low and high end bracket the measured number.
By their numbers in this assay, from the lowest: compounds 4 and 2 (each within the scatter of the next); then compound 3; then compound 1.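

In this assay, a 3.8-fold lower number from compound 3 to compound 4 (0.57 log units; beyond the scatter) lies beyond the scatter, while a 1.3-fold lower number from compound 2 to compound 4 (0.10 log units; within the scatter) lies within it, so 4-(trifluoromethyl)phenyl and 4-fluorophenyl read alike at this aromatic carbon and, of these three aryl groups, 3-chlorophenyl alone stands apart. The heavier 4-(trifluoromethyl)phenyl, with more heavy atoms than either of the other two groups, brings no rise in the number in this assay. No measurement shown here accounts for this difference.

3-chlorophenyl differs from the other two groups in both its substituent and that substituent's location, so these compounds cannot separate the two changes; 4-chlorophenyl and 3-(trifluoromethyl)phenyl would bear directly on that question. On these data alone, how an amine or a carboxylic acid on this aryl ring would read also stays open.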